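The source may hold more compounds than are shown below. What is called first, only, known or untested is meant among the compounds shown, and "the series" means these compounds.

Values so far in an ADME assay on MT4 cells (Homo sapiens) for cytotoxicity, read by MTT assay; on this read-out higher numbers stand for lower toxicity in this test and lower numbers for higher toxicity in this test:
compound 1 `O=C1c2ccccc2C(=O)N1CCOC(=S)N(C(=O)c1ccc(Br)cc1)c1ccc(Br)cc1` gives 73000 nM
compound 2 `Cc1ccc(N(C(=O)c2ccc([N+](=O)[O-])cc2)C(=S)OCCN2C(=O)c3ccccc3C2=O)cc1` gives 58000 nM
compound 3 `O=C1c2ccccc2C(=O)N1CCOC(=S)N(C(=O)c1c(Cl)cccc1Cl)c1ccc(Cl)cc1` gives 20000 nM

Compound 2 lies within the scatter of compound 1, while compound 3 lies lower than compound 2 by more than the scatter. The next compound to read is compound 4 `Cc1ccc(N(C(=O)c2cc(F)cc(F)c2)C(=S)OCCN2C(=O)c3ccccc3C2=O)cc1` which departs from compound 2 by one change: 3,5-difluorophenyl in place of 4-nitrophenyl on a carbonyl carbon that is, 3,5-difluorophenyl in place of 4-nitrophenyl on a carbonyl carbon.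

Going by the values given here, no two measured compounds differ in one place only, so the series gives no direct read on this change. Among the compounds with values here, the only guide is the span of the measured values in this assay and that span is narrow: compound 3 gives 20000 nM and compound 1 gives 73000 nM. The estimated 1.3-fold lower number from compound 2 to compound 4 (0.11 log units; within the scatter) is expected to stay within the scatter, with only a slight lean downward. For compound 4 the expected value is 45000 nM with an estimated range from 18000 nM to 110000 nM for this measurement.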

Compound 4, half-maximal cytotoxic concentration: 54000 nM
Compound 4: middle estimate off by 1.2-fold (0.08 log units), on the low side, and the stated range covers the measured number.
By their numbers in this assay, from the lowest: compound 3; then compounds 4, 2 and 1 (each within the scatter of the next).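

In this assay, going by these compounds alone, the first single-place comparison gives a 1.1-fold lower number from compound 2 to compound 4 (0.03 log units; within the scatter), so 3,5-difluorophenyl in place of 4-nitrophenyl on a carbonyl carbon leaves the read-out within the scatter. The entering group carries no hydrogen-bond acceptors and the leaving group does, yet this exchange produces no step beyond the scatter in this pair. No supporting measurement bears on why this step is so small.

As far as these compounds go, whether the same holds on the other parts of the shared core stays open, since this is a single pair on the background of compound 2. Also open, from the compounds shown here alone, is how this carbonyl position responds to a group that is not an aromatic ring of carbon only, such as an aliphatic amine, a carboxylic acid or a longer alkyl chain.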